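The compounds below may be only part of what the source reports. "The series", "measured", "known", "first", "only" and "open" are said of these compounds alone.

Measured so far:
compound 1, `CCOC(=O)/C=C/c1ccc(OCCCCCCN(CC)CC)c(OC)c1`: 1.8
compound 2, `CCOC(=O)/C=C/c1ccc(OCCCCCCN2CCCCC2)c(OC)c1`: 1.81
compound 3, `CCOC(=O)/C=C/c1ccc(OCCCCCCCCN(CC)CC)c(OC)c1`: 1.98

All three were measured in a physicochemical assay for lipophilicity, using the shake flask method, measured as octanol-water partition, at pH 7.4; a lower number here means a more polar compound, a higher number a more lipophilic compound. Compound 1 holds the lowest of the three numbers, yet its steps to the others, a number 0.01 log units higher from compound 1 to compound 2 (within the scatter) and a number 0.18 log units higher from compound 1 to compound 3 (within the scatter), both stay within the scatter, so the three compounds stand as one in this assay. Compound 4, `CCN(CC)CCCCCCOc1ccc(/C=C/C(=O)O)cc1OC`, differs from compound 1 by hydrogen in place of ethyl on an oxygen next to a carbonyl group. Among the measured compounds shown here, none of the measured steps touches this part of the molecule; each swapped the group on the saturated chain carbon, and none moved the number beyond the scatter. The step to compound 4 is therefore untested ground. Compound 4 is expected to come out lower, by a number 1.80 log units lower from compound 1 to compound 4 (beyond the scatter), at an estimated 0 with a range from -1.2 to 1.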

Compound 4, partition coefficient: 1.29
Estimate against measurement, compound 4: 1.29 log units below, outside the stated range (above it).
By their numbers in this assay, from the lowest: compound 4; then compounds 1, 2 and 3 (each within the scatter of the next).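

Hydrogen in place of ethyl on an oxygen next to a carbonyl group, which turns ethoxycarbonyl into carboxy, gives a number 0.51 log units lower from compound 1 to compound 4 (beyond the scatter) in this assay, the only step so far beyond the scatter. The earlier steps shown here, all on the saturated chain carbon, stayed within it. Nothing measured here explains this drop.

Going by these compounds, a methyl ester or a primary amide in place of the ethoxycarbonyl remains open. So does whether carboxy gives a similar step alongside the piperidin-1-yl group of compound 2.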